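This account rests on a few compounds, and the source may have more. Where it says the series, first, only, none or still open, it means among the compounds named here.

Working notes on the series. Compound 1 `Cc1nc2cc(C(=O)NCc3ccc(F)cc3)nn2c(-c2cc(F)c3c(c2C)CCCO3)c1[C@H](OC(C)(C)C)C(=O)O`, compound 2 `Cc1nc2cc(C(=O)NCc3ccc(F)c(C4CC4)c3)nn2c(-c2cc(F)c3c(c2C)CCCO3)c1[C@H](OC(C)(C)C)C(=O)O` and compound 3 `Cc1nc2cc(C(=O)NCc3ccc(F)cc3O)nn2c(-c2cc(F)c3c(c2C)CCCO3)c1[C@H](OC(C)(C)C)C(=O)O` share one core and differ only in the benzyl amide part. In an ADME assay on MT2 cells (Homo sapiens) for cytotoxicity (on this read-out higher numbers stand for lower toxicity in this test and lower numbers for higher toxicity in this test), compound 1 gives > 40000 nM, which is a limit of the assay and not a number. Compound 2 gives in this assay > 40000 nM, likewise a limit. Compound 3 stands in this assay at > 40000 nM, again a limit. The three measured steps are therefore not readable: a step that the two limits leave unreadable from compound 1 to compound 2, a step that the two limits leave unreadable from compound 1 to compound 3 and a step that the two limits leave unreadable from compound 2 to compound 3. Compound 3 thus stands exactly where the other two stand, namely at the limit of > 40000 nM in this assay, at which 3 of the 3 values shown sit.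

Compound 4 `Cc1nc2cc(C(=O)NCc3ccc(F)cc3S(C)(=O)=O)nn2c(-c2cc(F)c3c(c2C)CCCO3)c1[C@H](OC(C)(C)C)C(=O)O` is the next member to be measured in this assay. The change from compound 3 is methylsulfonyl in place of hydroxy on an aromatic carbon. Among the compounds with values here, two measured steps touch the same position of the benzyl ring, the introduction of the hydroxy group from compound 1 to compound 3 and the exchange of the whole benzyl group from compound 2 to compound 3; both sit between two limits and show no readable size. Within the data shown here, no step has yet moved any compound off the limit, so no step beyond the scatter is expected here, and the estimate for compound 4 in this assay is 45000 nM, with a range from 25000 nM to 90000 nM. The step that the limit leaves unreadable from compound 3 to compound 4 is accordingly expected to be flat, with the result most likely reported again only as a limit.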

Compound 4, half-maximal cytotoxic concentration: > 40000 nM
Compound 4 gave a limit, no number; the forecaster's own chance of this, stated with the estimate: 85%; the middle value is on the limit's open side.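

In this assay compound 4 gives > 40000 nM, again a limit and not a number. No step from compound 1, compound 2 or compound 3 to compound 4 can be read, and the series stays where it stood: the limit of > 40000 nM in this assay, at which 4 of the 4 values shown sit.

The compounds shown leave open whether any change in the benzyl amide part moves this read-out at all; none of them gives a number.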